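The compounds below may be only part of what the source reports. "The series", "measured", "known", "first", "only" and "open" are said of these compounds alone.

Measured so far in a physicochemical assay for acid dissociation:

- compound 1 `C=C(F)C(N)CCC(=O)O`: 8.32
- compound 2 `NC(/C=C\F)CCC(=O)O`: 9.35
- compound 3 `NC(C=C(F)F)CCC(=O)O`: 9.32

In this assay, compound 3 at 9.32 stands level with compound 2 within the scatter. Compound 1 gives 8.32. The number of compound 3 stands higher than that of compound 1, beyond the scatter.

Compound 4 `NC(CCC(=O)O)C(F)=C(F)F` differs from compound 3 by fluoro in place of hydrogen on a double-bonded chain carbon bound to a double-bonded chain carbon and a saturated chain carbon. Among the measured compounds shown here, only one measured step bears on this change. It is a number 1.03 log units higher from compound 1 to compound 2 (beyond the scatter), with 2-fluoroethenyl in place of 1-fluoroethenyl, and it is large. Compound 1 carries its fluoro at the place where a fluoro enters in compound 4, so that step points to a number in compound 4 lower than in compound 3 by a similar amount. The match is only partial, since that step moves a fluoro while this change adds one. The step expected is a number 1.02 log units lower from compound 3 to compound 4 (beyond the scatter), beyond the scatter. The estimate for compound 4 is 8.3, with an expected range from 7.8 to 8.8.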

Compound 4, acid dissociation constant: 7.87
The estimate for compound 4 lay 0.43 log units above the measured number; the range from low to high includes it.
By their numbers in this assay, from the lowest: compound 4; then compound 1; then compounds 3 and 2 (each within the scatter of the next).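

In this assay, among the compounds shown here, the change a number 1.45 log units lower from compound 3 to compound 4 (beyond the scatter) is the first where a fluoro replaces a hydrogen on the double-bonded chain carbon bound to a double-bonded chain carbon and a saturated chain carbon, whereas the earlier step, a number 1.03 log units higher from compound 1 to compound 2 (beyond the scatter), only moved a fluoro. Both steps point the same way among the compounds shown, with the number lower where a fluoro sits on this carbon, and none of the compounds goes against this. The new step also shows that this holds when fluoro atoms are already present on the other double-bonded carbon, as in compound 3. The compounds shown leave open whether a chloro or a methyl on this carbon would also go with a lower number, and whether the step would persist on a longer chain. Nothing shown gives a reason for the size or direction of this step.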